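A few compounds are considered here, and "the series" means these few. Any claim that something is new, unique, unknown or untested is made for them only; others in the source may bear on it.

Measured compounds:
Compound 1 `O=C(O)C1(Sc2nccc3ncccc23)CCC1` — in an assay on HEK293 cells for inhibition of solute carrier family 22 member 12 (Homo sapiens), read by scintillation counting, with a stated time of 12 min (a lower number here means a stronger inhibitor, a higher number a weaker inhibitor), compound 1 gives > 10000 nM, which is a limit of the assay and not a number.
Compound 2 `Nc1ccc2nccc(SC3(C(=O)O)CCC3)c2c1` — in this assay compound 2 gives 1790 nM.
Compound 3 `CNC(=O)COc1ccc2nccc(SC3(C(=O)O)CCC3)c2c1` — in this assay compound 3 gives > 10000 nM, again a limit rather than a number.

Compound 3 therefore stands at the weak end of what has been measured: its value is only a limit, and (the limit of > 10000 nM in this assay, at which 2 of the 3 values shown sit). Compound 4 `O=C(O)C1(Sc2ccnc3ccc(-c4ccc(F)cc4)cc23)CCC1` differs from compound 3 in one place: 4-fluorophenyl in place of (methylcarbamoyl)methoxy on an aromatic carbon. Among the measured compounds shown here, only one measured step touches this position, an at least 5.5-fold higher number from compound 2 to compound 3 (0.74 log units; beyond the scatter), where swapping amino for (methylcarbamoyl)methoxy weakened inhibition beyond the scatter. For the measured compounds named here, no measured step brings a 4-fluorophenyl to this place, so the new change has no direct precedent. Compound 1, which carries nothing at this position, also sits at the limit. The expectation for compound 4 is accordingly wide: the expected step of an at least 2.0-fold lower number from compound 3 to compound 4 (0.30 log units; that floor lies within the scatter) is a modest lowering of the number, with a real chance that the assay again reports only a limit. Compound 4 is expected to give about 5000 nM, within a range from 800 nM to 30000 nM.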

Compound 4, half-maximal inhibitory concentration: 159 nM
Compound 4: the middle estimate sits 31-fold (1.50 log units) above what was measured, outside the stated range (below it).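

Among the compounds shown here, this position accepts much more than the earlier compounds suggested: in this assay, putting 4-fluorophenyl in place of (methylcarbamoyl)methoxy gives an at least 62-fold lower number from compound 3 to compound 4 (1.79 log units; beyond the scatter), and putting it in place of amino gives an 11-fold lower number from compound 2 to compound 4 (1.05 log units; beyond the scatter). A group on this aromatic carbon can therefore strengthen inhibition well beyond what the amino group achieves, so the weak result with (methylcarbamoyl)methoxy reflects that group and does not count against substitution here in general. The first step is only a floor, as compound 3 carries a limit of the assay and not a number: the limit of > 10000 nM in this assay, at which 2 of the 4 values shown sit.

The compounds shown cannot tell whether the gain comes from the aromatic ring or from its fluorine, which plain phenyl or 4-chlorophenyl would help to separate. They also leave open how a saturated ring such as cyclohexyl would compare at this place.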